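Urea methyl transposition on the diisobutylamino core

A few compounds are considered here, and "the series" means these few. Any claim that something is new, unique, unknown or untested is made for them only; others in the source may bear on it.

Measured compounds:
compound 1, `Cc1ccc(NC(=O)Nc2cc(-c3ccccc3C(=O)NS(=O)(=O)C(F)(F)F)ccc2N(CC(C)C)CC(C)C)cc1`: > 1000 nM
compound 2, `Cc1ccc(NC(=O)N(C)c2cc(-c3ccccc3-c3nnn[nH]3)ccc2N(CC(C)C)CC(C)C)cc1`: 97 nM

In an assay on HeLa cells for inhibition of Indoleamine 2,3-dioxygenase 1 (Homo sapiens), with stated times of 1 h and 18 h (a higher number here means a weaker inhibitor, a lower number a stronger inhibitor), compound 1 returns only a limit, > 1000 nM. Among the measured compounds shown here, compound 2 gives 97 nM in this assay, the only numerical value so far. The other entry, that of compound 1, is a limit, (the limit of > 1000 nM in this assay, at which 1 of the 2 values shown sits). Compound 3, `Cc1ccc(N(C)C(=O)Nc2cc(-c3ccccc3-c3nnn[nH]3)ccc2N(CC(C)C)CC(C)C)cc1`, differs from compound 2 in one place: (methyl(4-methylphenyl)carbamoyl)amino in place of methyl((4-methylphenyl)carbamoyl)amino on an aromatic carbon. For the measured compounds named here, no measured pair isolates this change, so the expectation rests on compound 2 alone; the relocation of the methyl within the urea is expected to give a step of a 1.5-fold higher number from compound 2 to compound 3 (0.19 log units; within the scatter), not beyond the scatter. For compound 3 the estimated value in this assay is 150 nM, within 50 nM to 600 nM.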

Compound 3, half-maximal inhibitory concentration: 405 nM
The estimate for compound 3 lay 2.7-fold (0.43 log units) below the measured number; measured number inside the range.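

In this assay moving the methyl from the urea nitrogen on the aromatic carbon to the nitrogen bearing the 4-methylphenyl group gives a 4.2-fold higher number from compound 2 to compound 3 (0.62 log units; beyond the scatter) in this series. The two substituents hold the same atoms and the same counted donors and acceptors, so the placement of one methyl within the urea alone separates compound 2 from compound 3 at this position, ortho to the diisobutylamino group. Nothing measured here bears on the cause of this step.

Still open, from the compounds shown here alone, is how the urea with a methyl on both nitrogens, or with an ethyl in place of the methyl on either nitrogen, would compare. The urea with no methyl on either nitrogen and the 2-(1H-tetrazol-5-yl)phenyl group also remains to be placed against compound 2 and compound 3.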